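Working notes on cytotoxicity in a small series

A few compounds are considered here, and "the series" means these few. Any claim that something is new, unique, unknown or untested is made for them only; others in the source may bear on it.

compound 1 `COc1nc2ccccc2cc1/C=C/c1noc(-c2ccc(Br)cc2)n1`: > 195000 nM
compound 2 `COc1ccccc1-c1nc(/C=C/c2cc3ccccc3nc2OC)no1`: > 220000 nM

In an ADME assay on HepG2 cells (Homo sapiens) for cytotoxicity, read by sulforhodamine B assay, with a stated time of 48 h (on this read-out lower numbers stand for higher toxicity in this test and higher numbers for lower toxicity in this test), compound 1 gives > 195000 nM, which is a limit of the assay (the limit of > 195000 nM in this assay, at which 1 of the 2 values shown sits). In this assay compound 2 gives > 220000 nM, likewise a limit (the limit of > 220000 nM in this assay, at which 1 of the 2 values shown sits). The step that the two limits leave unreadable from compound 1 to compound 2 therefore cannot be read. Compound 2 thus stands only at a limit, with no number of its own. Compound 3 `COc1cccc(-c2nc(/C=C/c3cc4ccccc4nc3OC)no2)c1` differs from compound 2 by 3-methoxyphenyl in place of 2-methoxyphenyl on an aromatic carbon. Among the measured compounds shown here, no measured step in this assay is readable, so no direction beyond the scatter is expected. Compound 3 is expected near 220000 nM, within 110000 nM to 440000 nM, most likely again reported only as a limit. The step of a number no higher from compound 2 to compound 3 (the limit leaves the size open) is expected to be none beyond the scatter.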

Compound 3, half-maximal cytotoxic concentration: > 220000 nM
Compound 3: a limit, no number (the forecaster's own chance of this, stated with the estimate: 85%); the middle value lies on the limit itself.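

Among the compounds shown here, all of compound 1, compound 2 and compound 3 stand only at limits, and no step among them can be read. Left open is whether 4-bromophenyl, 2-methoxyphenyl and 3-methoxyphenyl differ at all in cytotoxicity.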